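The compounds below may be only part of what the source reports. "The series", "measured", "known", "first", "only" and "open" are said of these compounds alone.

In a functional assay on MIA PaCa-2 cells (Homo sapiens) for inhibition, read by MTT assay, with a stated time of 3 days (on this read-out lower numbers stand for stronger inhibition and higher numbers for weaker inhibition), compound 1 `CCCN(CCC)S(=O)(=O)c1ccc(S(=O)(=O)N2CCC[C@@H](C(=O)OCC)C2)cc1` gives > 10000 nM, which is a limit and not a number. Compound 2 `CCN(CC)S(=O)(=O)c1ccc(S(=O)(=O)N2CCC[C@@H](C(=O)N(C)C(C)C)C2)cc1` gives > 10000 nM, also a limit. Both therefore stand in the same place: the limit of > 10000 nM in this assay, at which 2 of the 2 values shown sit. Compound 3 `CCN(CC)S(=O)(=O)c1ccc(S(=O)(=O)N2CCC[C@@H](C(=O)NC3COC3)C2)cc1` carries (oxetan-3-yl)amino in place of isopropyl(methyl)amino on a carbonyl carbon [ (oxetan-3-yl)amino in place of isopropyl(methyl)amino on a carbonyl carbon ]. Among the measured compounds shown here, no measured step shows what this swap does. For the measured compounds named here, the only starting point is compound 2 at > 10000 nM, a limit. The estimated step that the limit leaves unreadable from compound 2 to compound 3 is therefore nothing beyond the usual scatter. For compound 3 the expected value is 15000 nM, within an estimated range from 6000 nM to 40000 nM.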

Compound 3, half-maximal inhibitory concentration: > 10000 nM
Compound 3: no number, only a limit; the forecaster's own chance of this, stated with the estimate: 85%; the middle value is on the limit's open side.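

Compound 3 gives > 10000 nM, a limit and not a number. Compound 2 also stands at a limit, so no step can be read between compound 2 and compound 3. The compounds shown leave open which structural change, if any, would give a measurable value in this assay.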